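Alkyl sulfamoyl ureas and carbamates as sterol acyltransferase inhibitors

The source may hold more compounds than are shown below. What is called first, only, known or untested is meant among the compounds shown, and "the series" means these compounds.

The series rests on a shared core carrying two isopropyl groups and a sulfonyl chain. Compound 1 `CCCCCCOS(=O)(=O)NC(=O)Nc1c(C(C)C)cccc1C(C)C` and compound 2 `CCCCCCCCCCOS(=O)(=O)NC(=O)Nc1c(C(C)C)cccc1C(C)C` carry a urea link, while compound 3 `CCCCCCCCCCCCOS(=O)(=O)NC(=O)Oc1c(C(C)C)cccc1C(C)C` carries a carbamate; how the core of compound 3 differs from that of compound 1 is not broken down here. In an assay on liver for inhibition of sterol O-acyltransferase 1 (Rattus norvegicus), using microsomes (a higher number here means a weaker inhibitor, a lower number a stronger inhibitor), compound 1 gives 27000 nM and compound 3 gives 13000 nM, the lower number of the two. For compound 2, this assay reports only a limit, > 10000 nM, consistent with the limit of > 10000 nM in this assay, at which 1 of the 3 values shown sits. The change from compound 1 to compound 2 is butyl in place of hydrogen on a saturated chain carbon, six bonds along the chain from an oxygen on an unsaturated carbon, and its size, a step that the limit leaves unreadable from compound 1 to compound 2, cannot be read.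

Compound 4 `CCCCCCCCCCCCCCCCOS(=O)(=O)NC(=O)Oc1c(C(C)C)cccc1C(C)C` is made from compound 3 by the same kind of change, (butyl in place of hydrogen on a saturated chain carbon, ten or more bonds along the chain from an oxygen on an unsaturated carbon). Since the earlier step that the limit leaves unreadable from compound 1 to compound 2 gave no readable size, the step of a 1.2-fold higher number from compound 3 to compound 4 (0.06 log units; within the scatter) is expected to be small, staying near the number of compound 3, 13000 nM. Compound 4 is therefore estimated at 15000 nM, between 6000 nM and 40000 nM.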

Compound 4, half-maximal inhibitory concentration: 10300 nM
Estimate against measurement, compound 4: 1.5-fold (0.16 log units) above; the range from low to high includes it.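

On the core carrying the carbamate, butyl in place of hydrogen on a saturated chain carbon, ten or more bonds along the chain from an oxygen on an unsaturated carbon, gives a 1.3-fold lower number from compound 3 to compound 4 (0.10 log units; within the scatter) in this assay. The matching change on the core carrying the urea link cannot be read, because compound 2 stands only as a limit: the limit of > 10000 nM in this assay, at which 1 of the 4 values shown sits.

A single readable step therefore does not show whether this change carries from one core to the other, and the two instances also sit at different places, the one on the urea side six bonds along the chain from an oxygen on an unsaturated carbon.

All the chains shown are plain saturated ones, and how a chain ending in an amine or a carboxylic acid would stand in this assay remains open on either core. Also open, going by these compounds, is whether a chain longer than that of compound 4 would read any differently on the core carrying the carbamate.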